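Adding a second chloro to the weakest analog

A few compounds are considered here, and "the series" means these few. Any claim that something is new, unique, unknown or untested is made for them only; others in the source may bear on it.

Of the compounds shown here, two of a shared core have been measured in an in vitro assay on COS-1 cells for inhibition of sodium-dependent dopamine transporter (Homo sapiens); on this read-out lower numbers stand for stronger inhibition and higher numbers for weaker inhibition. Compound 1 `COC(=O)C1=C(c2ccc(Cl)cc2)C2CCC1C2` gives 25100 nM in this assay. Compound 2 `COC(=O)C1=C(c2ccccc2Cl)C2CCC1C2` gives 372000 nM in this assay, the higher of the two numbers, with a gap to compound 1 that lies beyond the scatter. Compound 3 `COC(=O)C1=C(c2ccc(Cl)cc2Cl)C2CCC1C2` has not yet been measured in this assay. It differs from compound 2 in one place: chloro in place of hydrogen on an aromatic carbon, on an aromatic carbon of a six-membered aromatic ring of carbon only, meta to a chloro group and para to a large group. For the measured compounds named here, no step between measured compounds is known for this change, so the expectation rests on the two values above. Compound 3 is expected to show a 9.3-fold lower number from compound 2 to compound 3 (0.97 log units; beyond the scatter) in this assay, a lower number than compound 2. The estimate for compound 3 in this assay is 40000 nM, within a range from 10000 nM to 150000 nM.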

Compound 3, inhibition constant: 22900 nM
Compound 3: middle estimate off by 1.7-fold (0.24 log units), on the high side; measured number inside the range.
By their numbers in this assay, from the lowest: compounds 3 and 1 (each within the scatter of the next); then compound 2.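

In this assay, chloro in place of hydrogen on the aromatic carbon that lies meta to a chloro group and para to a large group gives a large step (a 16-fold lower number from compound 2 to compound 3 (1.21 log units; beyond the scatter)), so filling this position on compound 2 counts for much. The second chloro added to compound 1 gives a step within the scatter (a 1.1-fold lower number from compound 1 to compound 3 (0.04 log units; within the scatter)), so compound 1 and compound 3 cannot be told apart here, and the chloro of compound 2 contributes no readable step once this position carries a chloro. Nothing measured here accounts for either step.

The compounds shown leave open whether a methoxy group or an amine on this carbon would give a step of similar size. They also leave open where an aromatic ring with no chloro at all would stand on this read-out.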